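The source may report more compounds than this note shows. Statements on the series, on what has been measured and on what is new or still open speak of the compounds shown alone.

Measured so far:
- compound 1, `CCCCCCNC(=O)n1ccc(=O)n(C)c1=O`: 53 nM in an assay on HEK293 cells for inhibition of acid ceramidase (Rattus norvegicus), read by LC-MS, with a stated time of 30 min; on this read-out lower numbers stand for stronger inhibition and higher numbers for weaker inhibition
- compound 2, `CCCCNC(=O)n1ccc(=O)[nH]c1=O`: 8500 nM in this assay

Among the measured compounds shown here, compound 2 holds the highest of the two numbers; compound 1 sits at a far lower number, well beyond the scatter, though the two differ in more than one place and no single step between them is drawn.

Compound 3, `CCCCCNC(=O)n1ccc(=O)[nH]c1=O`, differs from compound 2 by methyl in place of hydrogen on a saturated chain carbon, four bonds along the chain from an amide-type nitrogen. For the measured compounds named here, no step between measured compounds covers this change alone. Compound 2 is expected to give way to a modestly lower number, in the direction of compound 1, so the estimated step is a 2.8-fold lower number from compound 2 to compound 3 (0.45 log units; beyond the scatter). For compound 3 the estimate is 3000 nM, range 800 nM to 10000 nM.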

Compound 3, half-maximal inhibitory concentration: 2100 nM
The estimate for compound 3 lay 1.4-fold (0.15 log units) above the measured number; low and high end bracket the measured number.
By their numbers in this assay, from the lowest: compound 1; then compound 3; then compound 2.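

In this assay methyl in place of hydrogen on a saturated chain carbon, four bonds along the chain from an amide-type nitrogen, gives a 4.0-fold lower number from compound 2 to compound 3 (0.61 log units; beyond the scatter) and so shows that this chain position responds to a single added carbon. The step is modest but beyond the usual scatter. Nothing available explains the change.

A single step cannot show whether a longer chain on the core of compound 3 would continue this direction. Nor does it show how an amine or a carboxylic acid at this position would compare with methyl.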